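This account rests on a few compounds, and the source may have more. Where it says the series, first, only, none or still open, it means among the compounds named here.

Measured in an assay on cells for inhibition of HSP60/HSP10 (Homo sapiens), with a stated time of 60 min; on this read-out higher numbers stand for weaker inhibition and lower numbers for stronger inhibition:
compound 1 `O=S(=O)(Nc1ccc(-c2nc3ccccc3o2)cc1)c1cccc(Cl)c1`: 54000 nM
compound 2 `O=S(=O)(Nc1ccc(-c2nc3ccccc3o2)cc1)c1ccccc1O`: > 100000 nM, a limit of the assay, not a number
compound 3 `O=S(=O)(Nc1ccc(-c2nc3ccccc3o2)cc1)c1ccccc1F`: > 100000 nM, a limit of the assay, not a number

Compound 3 stands at the limit of this assay, so no number is known for it. Compound 2 sits at that same limit, as the limit of > 100000 nM in this assay, at which 2 of the 3 values shown sit, records. For the measured compounds named here, compound 1 is the only member of the series with a read number. From compound 1 the change to compound 3 gave an at least 1.8-fold higher number from compound 1 to compound 3 (0.26 log units; that floor lies within the scatter), and the change to compound 2 gave an at least 1.8-fold higher number from compound 1 to compound 2 (0.26 log units; that floor lies within the scatter); the step between them is a step that the two limits leave unreadable from compound 2 to compound 3.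

Compound 4 `O=S(=O)(Nc1ccc(-c2nc3ccccc3o2)cc1)c1cccc(F)c1` differs from compound 3 in one place: 3-fluorophenyl in place of 2-fluorophenyl on a sulfonyl sulfur. Going by the values given here, no measured step covers this change directly. Compound 1 carries 3-chlorophenyl on the sulfonyl sulfur and gave a read number, while compound 3 with 2-fluorophenyl sits at the limit; the step of an at least 1.8-fold higher number from compound 1 to compound 3 (0.26 log units; that floor lies within the scatter) is the only one that bears on the move, and it is a floor within the scatter. Compound 4 is therefore expected to fall near compound 1 or at the limit, a step of an at least 1.1-fold lower number from compound 3 to compound 4 (0.04 log units; that floor lies within the scatter) expected. Compound 4 is estimated at 90000 nM, with a range from 35000 nM to 300000 nM.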

Compound 4, half-maximal inhibitory concentration: 71000 nM
Estimate against measurement, compound 4: 1.3-fold (0.10 log units) above; the measured number falls inside the stated range.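

In this assay the 3-fluorophenyl group on the sulfonyl sulfur gives a read number, so compound 1 no longer stands alone in this respect, and a read number is now seen with both 3-chlorophenyl and 3-fluorophenyl. The change from the 2-fluorophenyl and 2-hydroxyphenyl groups to 3-fluorophenyl gives an at least 1.4-fold lower number from compound 3 to compound 4 (0.14 log units; that floor lies within the scatter) and an at least 1.4-fold lower number from compound 2 to compound 4 (0.14 log units; that floor lies within the scatter), so neither move is established as a real gain, and the true size of each step stays hidden behind a limit: the limit of > 100000 nM in this assay, at which 2 of the 4 values shown sit. Fluoro in place of chloro gives a 1.3-fold higher number from compound 1 to compound 4 (0.12 log units; within the scatter), so this read-out does not separate the two groups.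

The step between compound 2 and compound 3 cannot be read, and the compounds shown leave open whether 2-chlorophenyl or 3-hydroxyphenyl on the sulfonyl sulfur would also give a read number, which would test whether the group's place on the ring, rather than its identity, decides the outcome. Also open, from the compounds shown here alone, is whether a larger group, such as a trifluoromethyl, an amine or a carboxylic acid on that phenyl ring, would move the number clearly beyond the scatter of compound 1 and compound 4.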